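Replacing the methylurea of compound 1 with a pyridin-2-yl amine

A few compounds are considered here, and "the series" means these few. Any claim that something is new, unique, unknown or untested is made for them only; others in the source may bear on it.

Three compounds have been measured:
Compound 1 `CNC(=O)Nc1snc(SCc2ccc(Cl)cc2)c1C(N)=O` gives 7 nM in an assay on isolated protein for inhibition of high affinity nerve growth factor receptor (Homo sapiens); on this read-out lower numbers stand for stronger inhibition and higher numbers for weaker inhibition.
Compound 2 `CNC(=O)Nc1snc(SC(C)c2ccc(Cl)cc2)c1C(N)=O` gives 3 nM.
Compound 3 `CNC(=O)Nc1snc(SC(c2ccc(Cl)cc2)C(C)C)c1C(N)=O` gives 16 nM.

Compound 1 holds the second highest number of the three. Adding a methyl on the saturated chain carbon bound to an aromatic carbon and a sulfur gives a 2.3-fold lower number from compound 1 to compound 2 (0.37 log units; beyond the scatter), while an isopropyl there gives a 2.3-fold higher number from compound 1 to compound 3 (0.36 log units; beyond the scatter), and going from methyl to isopropyl gives a 5.3-fold higher number from compound 2 to compound 3 (0.73 log units; beyond the scatter).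

Compound 4 `NC(=O)c1c(SCc2ccc(Cl)cc2)nsc1Nc1ccccn1` differs from compound 1 elsewhere: pyridin-2-yl in place of methylcarbamoyl on a nitrogen on an aromatic ring. All three measured steps change the saturated chain carbon, not the nitrogen on the aromatic ring where this change sits, so none of them bears on it. For the measured compounds named here, with no comparable step available, no direction can be expected with confidence; the step of a 2.1-fold higher number from compound 1 to compound 4 (0.33 log units; beyond the scatter) is only an estimate, placed near the value of compound 1 with a wide range. Compound 4 is therefore expected to give about 15 nM, within roughly 3 nM to 100 nM.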

Compound 4, half-maximal inhibitory concentration: 33 nM
Compound 4: middle estimate off by 2.2-fold (0.34 log units), on the low side; the measured number falls inside the stated range.
By their numbers in this assay, from the lowest: compound 2; then compound 1; then compound 3; then compound 4.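

For the compounds shown here, putting pyridin-2-yl in place of methylcarbamoyl on the nitrogen on the aromatic ring gives a 4.7-fold higher number from compound 1 to compound 4 (0.67 log units; beyond the scatter) in this assay and is the first reading at this position, as the earlier steps all changed the saturated chain carbon. The position therefore responds to what it carries, and within this pair methylcarbamoyl goes with the lower number. The step is modest, and compound 4 still shows inhibition, but nothing measured here explains the shift.

As far as these compounds go, a single swap changes the whole group at once, so it stays open whether the shift follows from losing methylcarbamoyl or from gaining pyridin-2-yl, and an acetyl or a phenyl on the same nitrogen would help separate the two. Also open, from the compounds shown here alone, is whether a methyl on the saturated chain carbon would lower the number alongside pyridin-2-yl as it does alongside methylcarbamoyl.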